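A few compounds are considered here, and "the series" means these few. Any claim that something is new, unique, unknown or untested is made for them only; others in the source may bear on it.

Measured compounds:
compound 1 `COCCN(C)S(=O)(=O)c1ccc(C)c(C#Cc2cc(Cl)ccc2OCC(=O)O)c1` — 77 nM
compound 2 `CC(C)S(=O)(=O)c1ccc(Cl)c(C#Cc2cc(Cl)ccc2OCC(=O)O)c1` — 67 nM
compound 3 `CN(C)S(=O)(=O)c1cncc(C#Cc2cc(Cl)ccc2OCC(=O)O)c1` — 289 nM

In a functional assay on cells for antagonist activity at prostaglandin D2 receptor 2 (Homo sapiens), read by flow cytometry, with a stated time of 10 min (on this read-out lower numbers stand for stronger inhibition and higher numbers for weaker inhibition), compound 1 gives 77 nM, the second highest of the three numbers. Compound 2 at 67 nM lies within the usual scatter of compound 1, so the two cannot be ordered, while compound 3 at 289 nM gives a clearly higher number than compound 1, beyond the scatter. Compound 4 `Cc1ccc(S(=O)(=O)N2CCCCC2C)cc1C#Cc1cc(Cl)ccc1OCC(=O)O` has not yet been tested. It differs from compound 1 in a single place: 2-methylpiperidin-1-yl in place of (2-methoxyethyl)(methyl)amino on a sulfonyl sulfur. Within the data shown here, no measured pair shows this kind of change, so the expected step from compound 1 to compound 4 in this assay is small, at most a modest downward move; the estimated step is a 1.3-fold lower number from compound 1 to compound 4 (0.11 log units; within the scatter). Compound 4 is therefore expected to give 60 nM, with a likely range from 25 nM to 150 nM.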

Compound 4, half-maximal inhibitory concentration: 310 nM
For compound 4 the middle estimate is 5.2-fold (0.71 log units) below the measured one; measured number above the stated range.
By their numbers in this assay, from the lowest: compounds 2 and 1 (each within the scatter of the next); then compounds 3 and 4 (each within the scatter of the next).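

In this assay, placing 2-methylpiperidin-1-yl instead of (2-methoxyethyl)(methyl)amino on the sulfonyl sulfur gives a 4.0-fold higher number from compound 1 to compound 4 (0.60 log units; beyond the scatter). This single-place pair shows that the group on this sulfur can move the read-out beyond the scatter, with the open-chain group of compound 1 giving the stronger inhibition of the two. No measurement shown explains this difference. As far as these compounds go, it remains open whether the ring itself or its methyl group goes with the weaker inhibition. Unsubstituted piperidin-1-yl or morpholin-4-yl on the same sulfur would help separate these possibilities.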